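Permeability notes on compound 3, a urea-to-amide exchange

This account rests on a few compounds, and the source may have more. Where it says the series, first, only, none or still open, it means among the compounds named here.

Measured so far:
Compound 1 `CC(C)(C)NC(=O)NCCS(=O)(=O)NC(=O)c1ccc(Nc2nc(NC3(c4ccc(Cl)cc4)CC3)nc(OCC(F)(F)F)n2)cc1` — 49 nm/s
Compound 2 `CCS(=O)(=O)NC(=O)c1ccc(Nc2nc(NC3(c4ccc(Cl)cc4)CC3)nc(OCC(F)(F)F)n2)cc1` — 28 nm/s

Both numbers come from a physicochemical assay for permeability, using PAMPA, at pH 7.4; a lower number here means that the compound crosses the layer more slowly, a higher number that the compound crosses the layer faster. Compound 1 and compound 2 sit within the scatter of each other: the step of a 1.8-fold lower number from compound 1 to compound 2 (0.24 log units; within the scatter) removes the whole ((tert-butyl)carbamoyl)amino group yet leaves the read-out essentially unchanged, so compound 1 has no separate standing among the two numbers beyond being one of two comparable values.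

Compound 3 `O=C(NS(=O)(=O)CCNC(=O)C1CC1)c1ccc(Nc2nc(NC3(c4ccc(Cl)cc4)CC3)nc(OCC(F)(F)F)n2)cc1` has not yet been measured in this assay. It differs from compound 1 by cyclopropyl in place of (tert-butyl)amino on a carbonyl carbon. Within the data shown here, the only step that bears on this is the one from compound 1 to compound 2, which touched the same part of the molecule more drastically and stayed within the scatter. A smaller edit in the same region is therefore expected to give no step beyond the scatter in this assay, in either direction. Compound 3 is expected to give 50 nm/s (from 25 nm/s to 100 nm/s). The estimated step is a 1.0-fold higher number from compound 1 to compound 3 (0.01 log units; within the scatter), no more than the scatter itself.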

Compound 3, apparent permeability: 1 nm/s
For compound 3 the middle estimate is 50-fold (1.70 log units) above the measured one; measured number outside the range, below it.
By their numbers in this assay, from the lowest: compound 3; then compounds 2 and 1 (each within the scatter of the next).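

In this assay, cyclopropyl in place of (tert-butyl)amino on a carbonyl carbon is a large step, a 49-fold lower number from compound 1 to compound 3 (1.69 log units; beyond the scatter), so this end of the chain is not silent, even though the earlier pair suggested it might be. (Cyclopropylcarbonyl)amino in place of hydrogen on a saturated chain carbon, two bonds along the chain from a sulfonyl sulfur, also gives a large step, a 28-fold lower number from compound 2 to compound 3 (1.45 log units; beyond the scatter), whereas the ((tert-butyl)carbamoyl)amino group at that place differs from hydrogen only within the scatter, a 1.8-fold lower number from compound 1 to compound 2 (0.24 log units; within the scatter), so among these three compounds the read-out depends on which group the chain carries and not merely on whether it carries one. No measurement at hand accounts for the low number of compound 3.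

The exchange alters the heavy-atom count, the hydrogen-bond donor count and the ring content together, so the compounds shown cannot assign the large step to any one of these differences. From the compounds shown here alone, whether a tert-butyl group or a cyclopropylamino group on the same carbonyl carbon would stand with compound 1 or with compound 3 remains open.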